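Hydroxy in place of 4-methylpiperazin-1-yl on the chain

The source may hold more compounds than are shown below. What is called first, only, known or untested is meant among the compounds shown, and "the series" means these compounds.

In a functional assay on K562 cells (Homo sapiens) for antiproliferative activity, read by MTT assay, with a stated time of 48 h (on this read-out higher numbers stand for weaker inhibition and lower numbers for stronger inhibition), compound 1 `Cn1cc(C2=C(c3nn(CCCN4CCCCC4)c4ncccc34)C(=O)N(c3ccccn3)C2=O)c2ccccc21` gives > 100000 nM, which is a limit and not a number. Among the compounds with values here, compound 2 `CN1CCN(CCCn2nc(C3=C(c4cn(C)c5ccccc45)C(=O)NC3=O)c3cccnc32)CC1` gives 46700 nM, the only true number so far. Compound 3 `Cn1cc(C2=C(c3nn(CCCO)c4ncccc34)C(=O)NC2=O)c2ccccc21` differs from compound 2 at one place: hydroxy in place of 4-methylpiperazin-1-yl on a saturated chain carbon, three bonds along the chain from an aromatic nitrogen. The 3-(4-methylpiperazin-1-yl)propyl becomes 3-hydroxypropyl. Within the data shown here, no measured step covers this change, so the only anchor is compound 2 at 46700 nM. The expected change a 1.2-fold lower number from compound 2 to compound 3 (0.07 log units; within the scatter) stays within the scatter, with no firm direction. Compound 3 is expected at 40000 nM, with an estimated range of 10000 nM to 100000 nM.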

Compound 3, half-maximal inhibitory concentration: 85800 nM
For compound 3 the middle estimate is 2.1-fold (0.33 log units) below the measured one; the measured number falls inside the stated range.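

In this assay, the first step read on this chain is a 1.8-fold higher number from compound 2 to compound 3 (0.26 log units; within the scatter), so 3-hydroxypropyl and 3-(4-methylpiperazin-1-yl)propyl are not told apart. For this pair, the number does not depend on keeping the six-membered non-aromatic ring on the chain. Compound 1 stands at a limit of the assay, not a number, and gives no readable step: the limit of > 100000 nM in this assay, at which 1 of the 3 values shown sits.

From the compounds shown here alone, whether a carboxylic acid or a primary amine at the end of the propyl chain would move the number beyond the scatter stays open. So does the effect of a longer chain.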